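A Second Methoxy Group and an Expected Antiproliferative Read-out

This account rests on a few compounds, and the source may have more. Where it says the series, first, only, none or still open, it means among the compounds named here.

Compound 2 `COc1ccc(-c2nc(C)c(C(=O)CSc3nc(-c4cccc(OC)c4)c(C#N)c(=O)[nH]3)s2)cc1` was measured in a functional assay on U-87MG ATCC cells for antiproliferative activity against U-87 MG (Homo sapiens), read by MTT assay, with a stated time of 48 h, tested at 10 uM (on this read-out higher numbers stand for a weaker effect at the one concentration tested and lower numbers for a stronger effect), where compound 2 gives 66.7%. Among the measured compounds shown here, its only measured relative is compound 1 `COc1ccc(-c2nc(C)c(C(=O)CSc3nc(-c4ccc(Cl)cc4)c(C#N)c(=O)[nH]3)s2)cc1`, which in this assay gives 92.7%. For the measured compounds named here, the one recorded step, a number 26 percentage points lower from compound 1 to compound 2 (beyond the scatter), leaves compound 2 with the lower of the two numbers and so with the stronger effect at the concentration tested. Compound 3 `COc1ccc(-c2nc(C)c(C(=O)CSc3nc(-c4ccc(OC)c(OC)c4)c(C#N)c(=O)[nH]3)s2)cc1` differs from compound 2 by methoxy in place of hydrogen on an aromatic carbon. Going by the values given here, no measured step exchanges a hydrogen for a methoxy group, so the single recorded step, which swaps one whole aryl group for another, bears on this change only loosely. With nothing closer to lean on, the expected step of a number 1.7 percentage points lower from compound 2 to compound 3 (within the scatter) in this assay is small and without a confident direction. Compound 3 is therefore estimated at 65% in this assay, within a range from 45% to 90%.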

Compound 3, a percentage reported as activity, at one concentration (the size of the read-out at that concentration, not a potency): 57.6%
Estimate against measurement, compound 3: 7.4 percentage points above, within the range that was stated.
By their numbers in this assay, from the lowest: compounds 3 and 2 (each within the scatter of the next); then compound 1.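

Among the compounds shown here, compound 3 gives the first direct reading of a methoxy group in place of hydrogen on this aryl ring, at the position ortho to the existing methoxy group. In this assay that change amounts to a number 9.1 percentage points lower from compound 2 to compound 3 (within the scatter), so the added group makes no clear difference here. The 3,4-dimethoxyphenyl group still stands well apart from 4-chlorophenyl, with a number 35.1 percentage points lower from compound 1 to compound 3 (beyond the scatter), which means that the gain seen with 3-methoxyphenyl survives the addition, but no measurement offered here accounts for either step.

On these data alone, whether an amine or a hydroxyl group at this same place would behave like methoxy remains open, as does the effect of a longer chain such as ethoxy. Each compound was read at one concentration only, so the numbers show a stronger or weaker effect at that concentration and nothing about other concentrations.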